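Side chain exchange on the shared core: clearance notes

A few compounds are considered here, and "the series" means these few. Any claim that something is new, unique, unknown or untested is made for them only; others in the source may bear on it.

Measured in an ADME assay on microsomes from liver (Homo sapiens) for metabolic stability, read by LC-MS, tested at 1 uM; on this read-out lower numbers stand for slow clearance and higher numbers for fast clearance:
- compound 1 `NCCOc1ccc([C@H]2CC[C@]3(CC2)OOC2(O3)C3CC4CC(C3)CC2C4)cc1`: < 7 mL.min-1.g-1, a limit
- compound 2 `N[C@H]1CC[C@@H](Oc2ccc([C@H]3CC[C@]4(CC3)OOC3(O4)C4CC5CC(C4)CC3C5)cc2)CC1`: < 7 mL.min-1.g-1, a limit

Compound 2 stands only at a limit, with no number behind it: in this assay compound 2 gives < 7 mL.min-1.g-1. The two measured compounds share one bound: the limit of < 7 mL.min-1.g-1 in this assay, at which 2 of the 2 values shown sit. Within the data shown here, the only measured step is a step that the two limits leave unreadable from compound 1 to compound 2, so it offers no size to carry forward.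

The next compound is compound 3 `O[C@H]1CC[C@H](NCCCOc2ccc([C@H]3CC[C@]4(CC3)OOC3(O4)C4CC5CC(C4)CC3C5)cc2)CC1`, and the change is 3-((4-hydroxycyclohexyl)amino)propyl in place of 4-aminocyclohexyl on an oxygen on an aromatic ring. Among the measured compounds shown here, no measured step covers this exchange, so the expectation rests on the shared limit alone. Compound 3 is expected close to that limit, and any visible step in this assay is expected towards faster clearance. The expected step is an at least 1.1-fold higher number from compound 2 to compound 3 (0.05 log units; that floor lies within the scatter). For compound 3 the estimated value is 8 mL.min-1.g-1, with an expected range from 4 mL.min-1.g-1 to 30 mL.min-1.g-1.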

Compound 3, intrinsic clearance in microsomes: < 7 mL.min-1.g-1
Compound 3 gave a limit, no number (the forecaster's own chance of this, stated with the estimate: 50%); middle value at least 1.1-fold (0.05 log units) away from the limit.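

The steps from compound 1 and from compound 2 to compound 3 cannot be read, since all three compounds sit at one shared bound: the limit of < 7 mL.min-1.g-1 in this assay, at which 3 of the 3 values shown sit.

From the compounds shown here alone, how far compound 1, compound 2 and compound 3 actually lie from that limit in this assay, and whether their side chains differ at all, stays open.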